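Swapping fluoro for methyl on a weak growth inhibitor

The source may hold more compounds than are shown below. What is called first, only, known or untested is meant among the compounds shown, and "the series" means these compounds.

Measured compounds:
- Compound 1 `CCOC(=O)c1nn(-c2ccccc2)c(-c2ccc(F)cc2)c1CNC(C)(C)C` gives 365000 nM; 179000 nM (2 entries) in two entries
- Compound 2 `CC(C)(C)NCc1c(C(=O)O)nn(-c2ccccc2)c1-c1ccc(F)cc1` gives > 680000 nM as a limit

Both compounds were tested in a functional assay on NCI-H460 cells (Homo sapiens) for inhibition, read by sulforhodamine B assay, with a stated time of 48 h; a lower number here means a stronger inhibitor of growth, a higher number a weaker inhibitor of growth. Compound 2 has no single number here, and its > 680000 nM is a limit of the assay. Compound 3 `Cc1ccc(-c2c(CNC(C)(C)C)c(C(=O)O)nn2-c2ccccc2)cc1` keeps the rest of compound 2 and carries methyl in place of fluoro on an aromatic carbon, para to a large group (methyl in place of fluoro on an aromatic carbon). Within the data shown here, no measured pair in this set shows what this change does, so no step beyond the usual scatter is expected in this assay. The expectation rests on compound 2 and its limit (the limit of > 680000 nM in this assay, at which 1 of the 2 values shown sits). The estimated step that the limit leaves unreadable from compound 2 to compound 3 is expected to stay within the scatter. For compound 3 the estimated value is 700000 nM with an expected range from 350000 nM to 1500000 nM and a good chance that the assay again reports only a limit.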

Compound 3, concentration for 50% growth inhibition: > 688000 nM
Compound 3 gave a limit, no number; the forecaster's own chance of this, stated with the estimate: 65%; the middle value does not contradict the limit.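

In this assay compound 2 gives > 680000 nM as a limit of the assay. Among these compounds, compound 3 gives > 688000 nM as a limit too, so no step between compound 2 and compound 3 can be read. The compounds shown leave open what 4-fluorophenyl to 4-methylphenyl does to growth inhibition in this assay.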